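A few compounds are considered here, and "the series" means these few. Any claim that something is new, unique, unknown or untested is made for them only; others in the source may bear on it.

Of the compounds shown here, three on one shared core have been measured so far. Compound 1 `CCOC(=O)C1=C(C)NC(C)=C(C(=O)OCC)C1c1ccc(OCC(=O)NCc2ccccc2)cc1` gives 8.33% in a functional assay on the whole organism (strain Wistar) for inhibition, with Rattus norvegicus as the target, read by paw edema, with stated times of 30 min and 0.5 h, at a dose of 20 mg/kg; on this read-out higher numbers stand for more inhibition at the one dose given (going by the name of the read-out) and lower numbers for less inhibition. Compound 2 `CCOC(=O)C1=C(C)NC(C)=C(C(=O)OCC)C1c1ccc(OCC(=O)Nc2ccc(C)cc2)cc1` reaches 43.9% in this assay, and compound 3 `CCOC(=O)C1=C(C)NC(C)=C(C(=O)OCC)C1c1ccc(OCC(=O)NNC(=O)c2ccccc2)cc1` gives 9.1%. The two steps that end at compound 3 thus differ sharply in size: a number 0.8 percentage points higher from compound 1 to compound 3 (within the scatter), whereas a number 34.8 percentage points lower from compound 2 to compound 3 (beyond the scatter). Compound 4 `CCOC(=O)C1=C(C)NC(C)=C(C(=O)OCC)C1c1ccc(OCC(=O)NNC(=O)c2sccc2Cl)cc1` differs from compound 3 in one place: 3-chlorothiophen-2-yl in place of phenyl on a carbonyl carbon. Within the data shown here, no measured step touches the group on the carbonyl carbon; the steps seen, a number 35.6 percentage points higher from compound 1 to compound 2 (beyond the scatter) and a number 34.8 percentage points lower from compound 2 to compound 3 (beyond the scatter), exchange the group on the amide-type nitrogen and so do not bear on this change. A step of a number 2.9 percentage points higher from compound 3 to compound 4 (within the scatter) is therefore expected, lying within the scatter. Compound 4 is estimated at 12%, between 0% and 35%.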

Compound 4, a percentage reported as inhibition, in the whole organism at one dose (the size of the read-out at that dose, not a potency): 10.6%
Beside the measured number, compound 4's estimate is 1.4 percentage points above it; the range from low to high includes it.
By their numbers in this assay, from the lowest: compounds 1, 3 and 4 (each within the scatter of the next); then compound 2.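

At the carbonyl carbon, the first change seen at this position gives a number 1.5 percentage points higher from compound 3 to compound 4 (within the scatter) and so shows that 3-chlorothiophen-2-yl and phenyl cannot be told apart here in this assay. The new group on the amide-type nitrogen gives a number 33.3 percentage points lower from compound 2 to compound 4 (beyond the scatter) and also a number 2.3 percentage points higher from compound 1 to compound 4 (within the scatter) and so leaves the large gap to compound 2 in place. Nothing available explains this result.

From the compounds shown here alone, it remains open whether an amine, a carboxylic acid or a longer chain on that carbonyl carbon would change the number.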